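The compounds below may be only part of what the source reports. "The series", "measured", "known", "first", "only" and "open" are said of these compounds alone.

Compound 3 `Nc1nn(C(=O)Nc2ccc(Cc3ccccc3)cc2)c2ccccc12` is the reference point of this account. Going by the values given here, in a functional assay on LOX IMVI cells (Homo sapiens) for inhibition, read by sulforhodamine B assay, with a stated time of 48 h (on this read-out lower numbers stand for stronger inhibition of growth and higher numbers for weaker inhibition of growth), compound 3 gives 477 nM, the lowest of the three numbers measured so far. Compound 1 `O=C(Nc1ccccc1OC(F)(F)F)Nc1n[nH]c2ccccc12` gives 22500 nM in this assay, and compound 2 `O=C(Nc1ccc(Cc2ccccc2)cc1)Nc1nn(C(=O)Nc2ccc(Cc3ccccc3)cc2)c2ccccc12` gives 71000 nM; each of these stands beyond the scatter from compound 3, so compound 3 is the most potent of the three measured compounds.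

Compound 4 `CCCCOc1ccc(NC(=O)n2nc(N)c3ccccc32)cc1` has not yet been measured in this assay. It differs from compound 3 in a single place: butoxy in place of benzyl on an aromatic carbon. Among the compounds with values here, no step between measured compounds mirrors this exchange, so nothing in the data fixes its direction or size. Compound 3 remains the only anchor, and the step from it is expected to be small, either none beyond the scatter or a mild weakening of growth inhibition, as a 1.9-fold higher number from compound 3 to compound 4 (0.28 log units; within the scatter) describes. Compound 4 is therefore estimated to give 900 nM in this assay, with a range from 250 nM to 3500 nM.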

Compound 4, concentration for 50% growth inhibition: 12200 nM
The estimate for compound 4 lay 14-fold (1.13 log units) below the measured number, and the stated range ends below it.
By their numbers in this assay, from the lowest: compound 3; then compounds 4 and 1 (each within the scatter of the next); then compound 2.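

In this assay, the aromatic carbon para to a large group proves sensitive to the choice of substituent: butoxy in place of benzyl brings a 26-fold higher number from compound 3 to compound 4 (1.41 log units; beyond the scatter) on the shared core. This is the first single-place comparison among the compounds shown, and it indicates that this position does not accept every group of similar size equally. The exchange removes a six-membered aromatic ring of carbon only and adds an oxygen, and nothing measured here bears on why the number rises or on which part of the exchange matters.

From the compounds shown here alone, it remains open whether a benzyloxy group, which keeps the ring and adds the oxygen, would stay close to compound 3. A pentyl chain, which has no ring and no oxygen, would test the other half of the exchange.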